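Triazolylmethyl aryl swap at the spirooxindole series

The source may hold more compounds than are shown below. What is called first, only, known or untested is meant among the compounds shown, and "the series" means these compounds.

Compound 1 `N#CC1=C(N)Oc2c(c3nc4ccccc4nc3c3ccccc23)C12C(=O)N(Cc1cnnn1-c1ccccc1Br)c1ccccc12` was tested in a functional assay on MCF7 cells (Homo sapiens) for antiproliferative activity, read by MTT assay, with a stated time of 48 h; a higher number here means a weaker inhibitor, a lower number a stronger inhibitor. Compound 1 gives only a limit, > 50000 nM. Compound 2 `N#CC1=C(N)Oc2c(c3nc4ccccc4nc3c3ccccc23)C12C(=O)N(Cc1cnnn1-c1ccc(Cl)c(Cl)c1)c1ccccc12` likewise gives only a limit, > 50000 nM. The step that the two limits leave unreadable from compound 1 to compound 2 is therefore not readable. For the measured compounds named here, compound 3 `COc1ccccc1-n1nncc1CN1C(=O)C2(C(C#N)=C(N)Oc3c(N)cc4nc5ccccc5nc4c32)c2ccccc21` stands as the only compound of the three with a number in this assay; compound 3 gives 28900 nM, the rest of the picture being (the limit of > 50000 nM in this assay, at which 2 of the 3 values shown sit). Compound 4 `Cc1cc(C)c(-n2nncc2CN2C(=O)C3(C(C#N)=C(N)Oc4c(N)cc5nc6ccccc6nc5c43)c3ccccc32)c(C)c1` differs from compound 3 by 2,4,6-trimethylphenyl in place of 2-methoxyphenyl on an aromatic nitrogen. Going by the values given here, the single measured change on the same aromatic nitrogen, a step that the two limits leave unreadable from compound 1 to compound 2, has no readable size, so no measured step informs direction here. The step of a 1.0-fold higher number from compound 3 to compound 4 (0.02 log units; within the scatter) is expected to stay within scatter. Compound 4 is expected in this assay at 30000 nM, with a range of 12000 nM to 50000 nM.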

Compound 4, half-maximal inhibitory concentration: > 50000 nM
Compound 4 was reported as a limit; the forecaster's own chance of this, stated with the estimate: 40%; middle value at least 1.6-fold (0.22 log units) away from the limit.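

For the compounds shown here, with 2,4,6-trimethylphenyl on this aromatic nitrogen, compound 4 gives only a limit in this assay, so the swap removes the one numbered value. The step is an at least 1.7-fold higher number from compound 3 to compound 4 (0.23 log units; that floor lies within the scatter): it sets a floor rather than a size, and a change beyond the scatter is not established. It is still the only readable step at this position, as steps between limits cannot be read, and most of the set now sits at the limit: the limit of > 50000 nM in this assay, at which 3 of the 4 values shown sit.

Open, going by these compounds, is how far compound 4 truly lies from compound 3. Also open, on these data alone, is whether a phenyl bearing an amine or a carboxylic acid at this position would give a number at all.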